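The compounds below may be only part of what the source reports. "The series", "measured", "known", "first", "only" and "open" are said of these compounds alone.

Measured compounds in an ADME assay on MDCK-MDR1 cells (Canis lupus familiaris) for permeability, in the apical to basolateral direction, with a stated time of 180 min; on this read-out higher numbers stand for higher permeability and lower numbers for lower permeability:
- compound 1, `CN(CCC#N)C(=O)c1ccc([C@H]2[C@@H](F)[C@@H](F)C[C@@H](F)[C@H]2F)cc1`: 8.1 10^-6 cm/s
- compound 2, `CN(CCC#N)C(=O)c1ccc(C2CCCCC2)cc1`: 18.7 10^-6 cm/s
- compound 3, `O=C(c1ccc([C@H]2[C@@H](F)[C@@H](F)C[C@@H](F)[C@H]2F)cc1)N1CC(O)C1`: 6.7 10^-6 cm/s

Compound 2 gives the highest of the three numbers, and its distances to compound 1 and to compound 3 are both beyond the scatter. Compound 1 and compound 3 share a core and differ in one place: 3-hydroxyazetidin-1-yl in place of (2-cyanoethyl)(methyl)amino on a carbonyl carbon This change gave a 1.2-fold lower number from compound 1 to compound 3 (0.08 log units; within the scatter), a step that does not rise above the scatter of this assay.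

Compound 4, `O=C(c1ccc(C2CCCCC2)cc1)N1CC(O)C1`, has not yet been measured. It stands to compound 2 as compound 3 stands to compound 1, by the same change: 3-hydroxyazetidin-1-yl in place of (2-cyanoethyl)(methyl)amino on a carbonyl carbon The core of compound 2 and that of compound 1 differ in a way that is not broken down here.

Given that the one earlier instance of this change, the step from compound 1 to compound 3, stayed within the scatter, the step from compound 2 to compound 4 is expected to be small as well, estimated as a 1.2-fold lower number from compound 2 to compound 4 (0.10 log units; within the scatter). Compound 4 is therefore estimated at 15 10^-6 cm/s, with a likely range from 8 10^-6 cm/s to 26 10^-6 cm/s.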

Compound 4, apparent permeability: 26 10^-6 cm/s
Estimate against measurement, compound 4: 1.7-fold (0.24 log units) below, within the range that was stated.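

In this assay, putting 3-hydroxyazetidin-1-yl in place of (2-cyanoethyl)(methyl)amino on a carbonyl carbon gave a 1.4-fold higher number from compound 2 to compound 4 (0.14 log units; within the scatter), so on this second core too the step does not rise above the scatter. Set beside the earlier instance, the two steps cannot be told apart: the same change on two cores in this assay, a 1.2-fold lower number (0.08 log units; within the scatter) from compound 1 to compound 3 and a 1.4-fold higher number (0.14 log units; within the scatter) from compound 2 to compound 4, 1.7-fold (0.23 log units) apart, within the scatter of two such steps. Going by these compounds alone, this shows that, for these two cores, the change carried over with no step beyond the scatter, but it rests on only two pairs and does not show that the same would hold on any other core.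

The compounds shown leave open how other groups on the carbonyl carbon would compare, such as a plain azetidin-1-yl without the hydroxy group, a morpholine or a simple dimethylamino group. They also do not tell which part of the change, the nitrile chain leaving or the hydroxy-bearing four-membered ring entering, would matter on its own.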